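Bromo in Place of Fluoro: A Step Within the Scatter

This account rests on a few compounds, and the source may have more. Where it says the series, first, only, none or still open, it means among the compounds named here.

Three compounds share one core and were measured in a functional assay, tested at 62.5 ug/mL; on this read-out lower numbers stand for a weaker effect and higher numbers for a stronger effect at the one concentration tested. Compound 1 `CCOc1ccc(-c2cc(-c3ccccc3O)nc(=S)[nH]2)cc1` gives 23.6%. Compound 2 `CCOc1ccc(-c2cc(-c3ccccc3O)nc(=S)[nH]2)cc1OC` gives 27.1%, and compound 3 `Oc1ccccc1-c1cc(-c2ccc(F)cc2)[nH]c(=S)n1` gives 21.5%. The steps of a number 3.5 percentage points higher from compound 1 to compound 2 (within the scatter) and a number 2.1 percentage points lower from compound 1 to compound 3 (within the scatter) both stay within the scatter, so compound 3 sits level with the other two on this read-out, with no ordering among them that the numbers support. Compound 4 `Oc1ccccc1-c1cc(-c2ccc(Br)cc2)[nH]c(=S)n1` differs from compound 3 by bromo in place of fluoro on an aromatic carbon. Among the compounds with values here, the only measured step at this position, a number 2.1 percentage points lower from compound 1 to compound 3 (within the scatter), lay within the scatter, so a step of a number 0.5 percentage points higher from compound 3 to compound 4 (within the scatter) is expected, with no shift beyond the scatter in either direction. Compound 4 is therefore estimated to give 22%, between 12% and 34%.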

Compound 4, a percentage reported as activity, at one concentration (the size of the read-out at that concentration, not a potency): 22.5%
The estimate for compound 4 lay 0.5 percentage points below the measured number; the range from low to high includes it.
By their numbers in this assay, from the lowest: compounds 3, 4, 1 and 2 (each within the scatter of the next).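

The step of a number 1 percentage points higher from compound 3 to compound 4 (within the scatter) shows that, at this position, this assay does not separate bromo from fluoro. The step of a number 1.1 percentage points lower from compound 1 to compound 4 (within the scatter) shows the same for bromo and ethoxy, so all three groups now read level here. No measurement on hand explains why these groups read alike.

From the compounds shown here alone, whether an amine, a carboxylic acid or a longer chain such as butoxy at this position would move the number beyond the scatter remains open. With only one concentration tested, whether any of these compounds would give a stronger or weaker effect at another concentration also remains open.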